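The source may hold more compounds than are shown below. What is called first, only, known or untested is meant among the compounds shown, and "the series" means these compounds.

Of the compounds shown here, three built on one shared core have been measured in a functional assay on JAR cells (Homo sapiens) for inhibition, read by MTT assay, with a stated time of 72 h, tested at 10 uM; on this read-out higher numbers stand for more inhibition at the one concentration tested (going by the name of the read-out) and lower numbers for less inhibition. Compound 1 `CCOC(=O)C1=C(Nc2ccccc2)S/C(=C\c2ccc([N+](=O)[O-])c(O)c2)C1=O` gives 51.2%, compound 2 `CCOC(=O)C1=C(Nc2ccccc2)S/C(=C\c2ccc[nH]2)C1=O` gives 49.2%, and compound 3 `CCOC(=O)C1=C(Nc2ccc(Br)cc2)S/C(=C\c2ccc[nH]2)C1=O` gives 41.5%. On the bare numbers compound 3 is the lowest of the three, yet its gap to compound 2 and its gap to compound 1 both lie within the scatter, so the three cannot be told apart in this assay .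

Compound 4 `CCOC(=O)C1=C(Nc2cccc(F)c2)S/C(=C\c2ccc[nH]2)C1=O` is the next compound, and it differs from compound 3 in one place: 3-fluorophenyl in place of 4-bromophenyl on an amine nitrogen. Within the data shown here, only one measured step touches the same part of the molecule, the one from compound 2 to compound 3, where bromo replaced hydrogen on an aromatic carbon and the read-out moved by a number 7.7 percentage points lower from compound 2 to compound 3 (within the scatter), a change within the scatter. Among the measured compounds shown here, the step to compound 4 undoes that bromo and brings in a fluoro on the same ring, for which no measured step exists. For the measured compounds named here, since the one related step stayed within the scatter, the expected step from compound 3 to compound 4 in this assay is a number 3.5 percentage points higher from compound 3 to compound 4 (within the scatter), that is, nothing beyond the scatter. Compound 4 is therefore estimated at 45% in this assay , with a range from 30% to 60%.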

Compound 4, a percentage reported as inhibition, at one concentration (the size of the read-out at that concentration, not a potency): 45.4%
Estimate against measurement, compound 4: 0.4 percentage points below; low and high end bracket the measured number.
By their numbers in this assay, from the lowest: compounds 3, 4, 2 and 1 (each within the scatter of the next).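

In this assay, swapping the group on the amine nitrogen gives a number 3.9 percentage points higher from compound 3 to compound 4 (within the scatter), and adding only the fluoro to the plain phenyl ring gives a number 3.8 percentage points lower from compound 2 to compound 4 (within the scatter). Until now only a bromo had been tried on this ring, so the new result shows that a second halogen, in a different place on the ring, also leaves the read-out within the scatter: phenyl, 4-bromophenyl and 3-fluorophenyl on this nitrogen cannot be told apart here, although the swap from compound 3 to compound 4 changes the halogen and its place at once and so cannot show what each change does alone. Nothing at hand explains these numbers or says what lies behind them.

Still open, on these data alone, is whether any group at this position can move the read-out beyond the scatter, such as a methoxy group or a carboxylic acid on the ring, or a cyclohexyl group or a longer chain in place of the ring. A reading at a single concentration also leaves open whether compounds this close would stay together across a range of concentrations.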